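From compound 2 to compound 4: an added amine chain

The source may report more compounds than this note shows. Statements on the series, on what has been measured and on what is new or still open speak of the compounds shown alone.

Measured in an ADME assay on microsomes from liver (Rattus norvegicus) for metabolic stability, using NADPH, with a stated time of 10 min; a lower number here means that less of the compound is left, a higher number that more of the compound is left:
- compound 1 `NCCCCN(C[C@H]1Cc2cccnc2CN1)[C@H]1CCCc2cccnc21`: 49%
- compound 2 `CN(C[C@H]1Cc2ncccc2CN1)[C@H]1CCCc2cccnc21`: 7%
- compound 3 `CN(C[C@@H]1Cc2ncccc2CN1)[C@H]1CCCc2cccnc21`: 1%

Compound 2, at 7%, lies within the scatter of compound 3 and well under compound 1. Little of either compound 2 or compound 3 survives the incubation.

The next compound to be tested is compound 4 `NC/C=C/CN(C[C@H]1Cc2ncccc2CN1)[C@H]1CCCc2cccnc21`. The change is 3-aminoprop-1-en-1-yl in place of hydrogen on a saturated chain carbon bound to an amine nitrogen.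

Within the data shown here, the one measured step, a number 6 percentage points lower from compound 2 to compound 3 (within the scatter), comes with the fact that compounds 2 and 3 differ only in the configuration as drawn, so it offers little guidance on a new chain. The better pointer is compound 1, which also carries a chain bearing an amino group and stands at 49%. Its core is not identical to that of compound 2, so this is only a loose comparison resting on a single compound.

A rise beyond the scatter therefore seems likely, though its size is uncertain. The expected change is a number 23 percentage points higher from compound 2 to compound 4 (beyond the scatter). For compound 4 the estimated value is 30%, with an expected range from 10% to 60%.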

Compound 4, percent of the compound remaining: 11%
For compound 4 the middle estimate is 19 percentage points above the measured one; low and high end bracket the measured number.
By their numbers in this assay, from the lowest: compounds 3, 2 and 4 (each within the scatter of the next); then compound 1.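

In this assay, this is the first change shown at this place that adds atoms rather than altering configuration, and 3-aminoprop-1-en-1-yl in place of hydrogen on a saturated chain carbon bound to an amine nitrogen gives no reading beyond the scatter (a number 4 percentage points higher from compound 2 to compound 4 (within the scatter)). On this core, then, the chain does not separate compound 4 from compound 2, and with compound 4 at 11% little of it survives the incubation. Nothing available here bears on why this is so.

Compound 1 differs from compound 4 in more than one place, so the compounds shown do not settle what its chain would do on this core. Also open, on these data alone, is whether a longer chain, or a chain carrying a carboxylic acid in place of the amine, would read differently at this place.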